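Saturating the side chain across two cores

The source may report more compounds than this note shows. Statements on the series, on what has been measured and on what is new or still open speak of the compounds shown alone.

The series holds two pairs built on different cores. Compound 1 `CCCCC/C=C\C/C=C\CCCCCCCc1cc(=O)c2c(O)cc(O)c(C)c2o1` and compound 3 `CCCCCCCCCCCCCCCc1cc(=O)c2c(O)cc(O)c(C)c2o1` share one core; compound 2 `CCCCC/C=C\C/C=C\CCCCCCCC1(O)CC(=O)c2c(O)cc(OCOC)cc2O1` and compound 4 `CCCCCCCCCCCCCCCC1(O)CC(=O)c2c(O)cc(OCOC)cc2O1` share another. The difference between the two cores is not broken down here.

In a functional assay on MDA-MB-231 cells (Homo sapiens) for antiproliferative activity, read by MTT assay (on this read-out higher numbers stand for weaker inhibition and lower numbers for stronger inhibition), compound 1 gives 6790 nM, and compound 3 gives 6790 nM. The step between them, (octyl in place of deca-1,4-dien-1-yl on a saturated chain carbon, seven bonds along the chain from an aromatic carbon), reads no change at the digits printed from compound 1 to compound 3 (within the scatter). Compound 2, in this assay, gives 16100 nM; it is the highest of the three numbers, and its gap to compound 1 and to compound 3 lies beyond the scatter.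

Compound 4 is not yet measured. It differs from compound 2 by octyl in place of deca-1,4-dien-1-yl on a saturated chain carbon, seven bonds along the chain from a saturated ring carbon. Among the compounds with values here, this is the same kind of change as the one from compound 1 to compound 3, not the same: there the place is seven bonds along the chain from an aromatic carbon, here it is seven bonds along the chain from a saturated ring carbon. Only one measured occurrence of this change exists, so the expectation rests on it alone.

The step from compound 2 to compound 4 in this assay is expected to be a 1.0-fold lower number from compound 2 to compound 4 (0.00 log units; within the scatter), because the same change gave no change at the digits printed from compound 1 to compound 3 (within the scatter). Compound 4 is therefore estimated at 16000 nM, with a range from 8000 nM to 32000 nM in this assay.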

Compound 4, half-maximal inhibitory concentration: > 87000 nM
Compound 4: a limit, no number; the forecaster's own chance of this, stated with the estimate: 10%; middle value at least 5.4-fold (0.73 log units) away from the limit.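

Carrying octyl in place of deca-1,4-dien-1-yl onto the core of compound 2 gives an at least 5.4-fold higher number from compound 2 to compound 4 (0.73 log units; beyond the scatter) in this assay, so the result on the core of compound 1 does not transfer to this core: the same change on two cores in this assay, no change at the digits printed (within the scatter) from compound 1 to compound 3 and an at least 5.4-fold higher number (0.73 log units; beyond the scatter) from compound 2 to compound 4, at least 5.4-fold (0.73 log units) apart, beyond the scatter of two such steps

Compound 4 stands at > 87000 nM in this assay, which is a limit of the assay and not a number.

The two pairs show that the outcome of this change differs with the core, but they do not show how large the step on the core of compound 2 really is, which part of that core goes with the split, or whether the split would hold on any further core.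

The compounds shown carry only these two chains, so it stays open how a chain with a single double bond, a shorter chain, or a chain ending in a carboxylic acid or an amine would read on either core. The difference between the two cores is also not broken down, and a pair on the core of compound 2 with a free hydroxyl in place of the methoxymethoxy group would be needed to test one part of it.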